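This account rests on a few compounds, and the source may have more. Where it says the series, first, only, none or still open, it means among the compounds named here.

In a functional assay on HCT-116 cells (Homo sapiens) for inhibition, read by MTT assay, with a stated time of 48 h (a higher number here means a weaker inhibitor, a lower number a stronger inhibitor), three compounds that share one core differ only in the saturated chain carrying the hydroxycarbamoyl group. Compound 1 (`O=C(CCCOc1no[n+]([O-])c1S(=O)(=O)c1ccccc1)NO`) gives 3830 nM and compound 2 (`O=C(CCCCCCOc1no[n+]([O-])c1S(=O)(=O)c1ccccc1)NO`) gives 4690 nM. Compound 3 (`O=C(CCCCCCCOc1no[n+]([O-])c1S(=O)(=O)c1ccccc1)NO`) gives 2610 nM and so stands within the scatter of both. Compound 4 (`O=C(COCCOc1no[n+]([O-])c1S(=O)(=O)c1ccccc1)NO`) has (hydroxycarbamoyl)methoxy in place of 5-(hydroxycarbamoyl)pentyl on a saturated chain carbon, two bonds along the chain from an oxygen on an aromatic ring. The chain steps are all small (a 1.2-fold higher number from compound 1 to compound 2 (0.09 log units; within the scatter) and a 1.5-fold lower number from compound 1 to compound 3 (0.17 log units; within the scatter) and a 1.8-fold lower number from compound 2 to compound 3 (0.25 log units; within the scatter)), so no step beyond the scatter is expected in this assay. Among the measured compounds shown here, no measured compound has an oxygen inside this chain, which widens the uncertainty. The expected step is a 1.5-fold higher number from compound 3 to compound 4 (0.16 log units; within the scatter). Compound 4 is estimated at 3800 nM, with an expected range from 1800 nM to 8000 nM.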

Compound 4, half-maximal inhibitory concentration: 13400 nM
For compound 4 the middle estimate is 3.5-fold (0.55 log units) below the measured one, and the stated range ends below it.
By their numbers in this assay, from the lowest: compounds 3, 1 and 2 (each within the scatter of the next); then compound 4.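

Among the compounds shown here, replacing the all-carbon chain with one carrying (hydroxycarbamoyl)methoxy is the first change here to go beyond the scatter in this assay: a 5.1-fold higher number from compound 3 to compound 4 (0.71 log units; beyond the scatter), a 2.9-fold higher number from compound 2 to compound 4 (0.46 log units; beyond the scatter) and a 3.5-fold higher number from compound 1 to compound 4 (0.54 log units; beyond the scatter). So this position tolerates differences among the all-carbon chains of compounds 1, 2 and 3, yet it does respond to this change, and compound 4 is the weakest of the four. No measured evidence accounts for this result.

Compound 4 differs from the others in both chain length and the oxygen inside the chain, so the effects of the two remain unseparated. An all-carbon chain of the same length as in compound 4, or an amine in place of that oxygen, would help to separate them.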